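The source may hold more compounds than are shown below. What is called first, only, known or untested is meant among the compounds shown, and "the series" means these compounds.

Three compounds sharing one core were tested in a functional assay on NPC-TW01 cells (Homo sapiens) for inhibition, read by MTT assay, with a stated time of 72 h; a lower number here means a stronger inhibitor of growth, a higher number a weaker inhibitor of growth. Compound 1 `COC(=O)c1nc(C)n(-c2ccc(C(F)(F)F)cc2)n1` carries a methyl group at the position of interest. In this assay compound 1 gives only a limit, > 100000 nM, a value at which (the limit of > 100000 nM in this assay, at which 1 of the 3 values shown sits). Compound 2 `COC(=O)c1nc(C2CCCCC2)n(-c2ccc(F)cc2)n1` gives 30500 nM in this assay. Compound 3 `COC(=O)c1nc(C2CCCC2)n(-c2ccc(C(F)(F)F)cc2)n1` gives 56400 nM in this assay, the higher of the two numbers, with compound 2 nearest and the gap between them within the usual scatter. Among the measured compounds shown here, the only measured step reaching compound 3 is an at least 1.7-fold lower number from compound 1 to compound 3 (0.24 log units; that floor lies within the scatter), whose floor also lies within the scatter.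

Compound 4 `COC(=O)c1nc(C2CCCCC2)n(-c2ccc(C(F)(F)F)cc2)n1` differs from compound 3 by cyclohexyl in place of cyclopentyl on an aromatic carbon. For the measured compounds named here, no measured step covers this exact change. Compound 2 also carries a cyclohexyl group, though with a different substituent elsewhere in the molecule, and shows 30500 nM, while compound 3 shows 56400 nM. Compound 4 is therefore expected to sit close to compound 3, with an estimated step of a 1.4-fold lower number from compound 3 to compound 4 (0.15 log units; within the scatter) that stays within the scatter. Compound 4 is estimated at 40000 nM, expected to fall between 15000 nM and 100000 nM.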

Compound 4, concentration for 50% growth inhibition: > 100000 nM
Compound 4: no number, only a limit (the forecaster's own chance of this, stated with the estimate: 12%); middle value at least 2.5-fold (0.39 log units) away from the limit.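

With cyclohexyl in place of cyclopentyl there is an at least 1.7-fold higher number from compound 3 to compound 4 (0.24 log units; that floor lies within the scatter) in this assay, so the larger ring brings no gain at this position, although a real loss is not established. Among the compounds shown here, with cyclohexyl held constant, trifluoromethyl in place of fluoro on an aromatic carbon gives an at least 3.2-fold higher number from compound 2 to compound 4 (0.51 log units; beyond the scatter), the first step in this set that clearly exceeds the scatter, showing that the group elsewhere in the molecule can change the reading while this position stays the same. The step between compound 1 and compound 4 cannot be read, and compound 4 joins compound 1 at the limit of the assay: the limit of > 100000 nM in this assay, at which 2 of the 4 values shown sit.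

The compounds shown leave open whether fluoro in place of trifluoromethyl would also lower the number with cyclopentyl or methyl at this position. They also leave open how an amine or a longer chain here would read in this assay.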